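The compounds below may be only part of what the source reports. "The series", "measured", "known", "first", "only" and "open" are said of these compounds alone.

Among the compounds with values here, in a functional assay on U-87MG ATCC cells (Homo sapiens) for cytotoxicity, read by MTT assay, with a stated time of 48 h (on this read-out higher numbers stand for weaker inhibition and lower numbers for stronger inhibition), compound 1 `CC(=NNC(=S)Nc1ccc(Cl)cc1)c1ccccn1` gives 1.7 nM and compound 2 `CC(=NNC(=S)Nc1ccc(F)cc1)c1ccccn1` gives 10 nM, so compound 2 holds the higher of the only two numbers available, which means the weaker inhibition. The next compound to be tested is compound 3 `CC(=NNC(=S)Nc1ccc([N+](=O)[O-])cc1)c1ccccn1`, which keeps the shared core and replaces one group: nitro in place of fluoro on an aromatic carbon. In words, this is nitro in place of fluoro on an aromatic carbon, para to a large group.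

Within the data shown here, only one measured step bears on this change: a 5.9-fold higher number from compound 1 to compound 2 (0.77 log units; beyond the scatter). It is also a swap of one group on an aromatic carbon, it is modest in size, and it lies beyond the scatter. That step involves only fluoro and chloro, so the data say nothing directly about nitro, and the direction of any change remains uncertain. Among the measured compounds shown here, compound 2 sits at the higher end of the measured pair, so a modest move toward a lower number is expected, no larger than the step already seen. The estimated change is a 2.0-fold lower number from compound 2 to compound 3 (0.30 log units; within the scatter). For compound 3 the expected value is 5 nM, with an estimated range from 1 nM to 25 nM.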

Compound 3, half-maximal inhibitory concentration: 160 nM
Estimate against measurement, compound 3: 32-fold (1.51 log units) below; the measured number lies above the stated range.
By their numbers in this assay, from the lowest: compound 1; then compound 2; then compound 3.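

The halogen swap had shown only a modest shift at this position, whereas nitro in place of fluoro on the aromatic carbon gives a large one in this assay, with a 16-fold higher number from compound 2 to compound 3 (1.20 log units; beyond the scatter) and, against the chloro compound, a 94-fold higher number from compound 1 to compound 3 (1.97 log units; beyond the scatter). So the position tolerates far less than the two halogens suggested: the choice of group here can move the number by much more than the earlier step, and all three compounds now stand apart beyond the scatter, with compound 3 the weakest of them. Nothing given here explains why nitro, which brings more heavy atoms and two hydrogen-bond acceptors where fluoro brings none, gives so much weaker an inhibition.

With only chloro, fluoro and nitro at this position, the compounds shown cannot separate the effect of group size from that of the acceptors, and it remains open where a methyl, a methoxy, an amine or a carboxylic acid would fall on this scale. They also leave open how the compound with a plain hydrogen at this position compares, and whether the same order would hold in other cell lines.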